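The source may report more compounds than this note shows. Statements on the series, on what has been measured and on what is new or still open speak of the compounds shown alone.

Measured in a functional assay on HEK239 cells (Homo sapiens) for inhibition, read by ELISA, with a stated time of 24 h; a lower number here means a stronger inhibitor of growth, a higher number a weaker inhibitor of growth:
- Compound 1 `O=C(Cl)/C=C/c1ccccc1OC(=O)c1ccccc1`: > 100000 nM (a limit)
- Compound 2 `O=C(/C=C/c1ccccc1O)NO`: 49800 nM

Compound 1 gives no true number in this assay. Its result of > 100000 nM is a limit of the assay and only marks where the measurement stops.

Compound 3 `CC(=O)ONC(=O)/C=C/c1ccccc1OC(=O)c1ccccc1` keeps the core of compound 1 but has acetoxyamino in place of chloro on a carbonyl carbon.

Within the data shown here, no measured pair shows what this swap does, so any forecast is uncertain. Among the measured compounds shown here, the only actual number available comes from compound 2, at 49800 nM, and it serves as a rough guide to the range.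

A small move toward stronger inhibition of growth is expected: an at least 2.0-fold lower number from compound 1 to compound 3 (0.30 log units; that floor lies within the scatter). A result that again reaches only the limit would not be surprising. The estimated value for compound 3 is 50000 nM, with an expected range from 15000 nM to 100000 nM.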

Compound 3, concentration for 50% growth inhibition: 18600 nM
Compound 3: the middle estimate sits 2.7-fold (0.43 log units) above what was measured, within the range that was stated.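

In this assay, acetoxyamino in place of chloro on a carbonyl carbon gives an at least 5.3-fold lower number from compound 1 to compound 3 (0.73 log units; beyond the scatter). Among these compounds, this is the first sign that what sits on this carbonyl carbon can change growth inhibition, a point that the values of compound 1 and compound 2 alone could not settle. Compound 1 rests at a limit, and because of that the step gives only a floor and not its full size: the limit of > 100000 nM in this assay, at which 1 of the 3 values shown sits.

The acetoxyamino group enters as a whole, so the step cannot tell whether its acetyl part or its nitrogen matters more. On these data alone, how a simple amine or a carboxylic acid on the same carbonyl carbon would compare remains open, as does whether changes elsewhere on the shared core would move growth inhibition at all.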